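A few compounds are considered here, and "the series" means these few. Any claim that something is new, unique, unknown or untested is made for them only; others in the source may bear on it.

Measured so far:
compound 1 `COc1ccc(-c2cc(NO)c(C(=O)Nc3ccccc3)c(=O)o2)cc1` — 16200 nM
compound 2 `CNC(=O)c1c(NO)cc(-c2ccc(Cl)cc2)oc1=O` — > 20000 nM

In an ADME assay on Huh-7 cells (Homo sapiens) for cytotoxicity, read by a luciferase reporter and WST assay, with a stated time of 3 days (a higher number here means that more compound is tolerated, a lower number that less compound is tolerated), compound 1 gives 16200 nM. In this assay compound 2 gives only a limit, > 20000 nM, and this is the limit of > 20000 nM in this assay, at which 1 of the 2 values shown sits. Compound 3 `CNC(=O)c1c(NO)cc(-c2ccc(OC)cc2)oc1=O` differs from compound 2 by methoxy in place of chloro on an aromatic carbon, in words methoxy in place of chloro on an aromatic carbon. For the measured compounds named here, no measured step between compounds of this set tells how large such a change is; the two values at hand give no sign of a shift beyond the usual scatter, so no step beyond it is expected. The estimate for compound 3 in this assay is 20000 nM, within 8000 nM to 50000 nM, which means an expected step of a number no higher from compound 2 to compound 3 (the limit leaves the size open).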

Compound 3, half-maximal cytotoxic concentration: > 20000 nM
Compound 3: only a limit was reported; the forecaster's own chance of this, stated with the estimate: 55%; the middle value lies on the limit itself.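

In this assay compound 3 gives > 20000 nM, which is a limit and not a number. The step for methoxy in place of chloro cannot be read, and compound 2 and compound 3 stand at the same limit: the limit of > 20000 nM in this assay, at which 2 of the 3 values shown sit. Methyl in place of phenyl on the amide-type nitrogen, with methoxy kept, gives an at least 1.2-fold higher number from compound 1 to compound 3 (0.09 log units; that floor lies within the scatter). From the compounds shown here alone, the true size of either change stays open. So does whether an amine or a carboxylic acid on that aromatic carbon, or a longer chain on that nitrogen, would give a readable value.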